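Trimming the Urea Substituent of Compound 1

The source may hold more compounds than are shown below. What is called first, only, known or untested is meant among the compounds shown, and "the series" means these compounds.

Compound 1 `CC(C)(C)NC(=O)N1CC1C#N` is the weaker of the two measured compounds: in a functional assay on L1210 cells (Mus musculus) for inhibition, read by MTT assay (a lower number here means a stronger inhibitor, a higher number a weaker inhibitor), compound 1 gives 132000 nM, whereas compound 2 `N#CC1CN1C(=O)Nc1ccc(C(F)(F)F)cc1` gives 7800 nM, a gap well beyond the scatter. Compound 3 `CCNC(=O)N1CC1C#N` differs from compound 1 by ethyl in place of tert-butyl on an amide-type nitrogen. Among the compounds with values here, no measured pair in this set isolates such a change, so only a small step is expected, a 1.2-fold lower number from compound 1 to compound 3 (0.08 log units; within the scatter), with no clear direction beyond the scatter. For compound 3 the estimate in this assay is 110000 nM, with a range from 35000 nM to 350000 nM.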

Compound 3, half-maximal inhibitory concentration: 14000 nM
Estimate against measurement, compound 3: 7.9-fold (0.90 log units) above; the whole stated range lies above it.
By their numbers in this assay, from the lowest: compounds 2 and 3 (each within the scatter of the next); then compound 1.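

In this assay, within the data shown here, the group on this amide-type nitrogen proves to matter: ethyl in place of tert-butyl gives a 9.4-fold lower number from compound 1 to compound 3 (0.97 log units; beyond the scatter) and is the first step here to isolate this position. The two groups match in having no ring, no hydrogen-bond donors or acceptors and no net charge, and differ in carbon count, though a single pair cannot show that carbon count governs the result. Nothing measured here accounts for the step. As far as these compounds go, whether methyl would continue this direction remains open, as does the effect of a longer chain such as n-butyl or of a cyclopropyl group.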